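The source may report more compounds than this note shows. Statements on the series, on what has been measured and on what is new or still open speak of the compounds shown alone.

In an ADME assay on RAW264.7 cells (Mus musculus) for cytotoxicity, read by MTT assay, with a stated time of 24 h, in the presence of a further agent that is not named here (a higher number here means a weaker inhibitor, a lower number a stronger inhibitor), three compounds sharing one core have been measured so far. Compound 1 `O=C1OC(Cc2nc(-c3ccccc3)no2)c2ccccc21` gives > 40000 nM, which is a limit of the assay and not a number. Compound 2 `O=C1OC(Cc2nc(Cc3ccccc3)no2)c2ccccc21` gives > 40000 nM, again a limit. Compound 3 `O=C1OC(Cc2nc(-c3ccc(Oc4ccccc4)cc3)no2)c2ccccc21` gives > 40000 nM, also a limit. For the measured compounds named here, compound 3 therefore has no exact value and stands level with the other two on the only reading available: the limit of > 40000 nM in this assay, at which 3 of the 3 values shown sit.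

Compound 4 `O=C1OC(Cc2nc(-c3ccc(-c4ccccc4)cc3)no2)c2ccccc21` differs from compound 3 at a single place, on an aromatic carbon of a six-membered aromatic ring of carbon only, para to a large group: phenyl in place of phenoxy on an aromatic carbon. In short, phenyl stands in place of phenoxy.

Two measured changes bear on this. Benzyl in place of phenyl on an aromatic carbon gave a step that the two limits leave unreadable from compound 1 to compound 2. Phenoxy in place of hydrogen on an aromatic carbon gave a step that the two limits leave unreadable from compound 1 to compound 3. Neither has a readable size, yet neither brought a value out of the limit. No step beyond the scatter is therefore expected in this assay, and no direction can be named. The expected step is a step that the limit leaves unreadable from compound 3 to compound 4. Compound 4 is estimated at 50000 nM, with an expected range from 25000 nM to 100000 nM, and the assay may well report only a limit again.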

Compound 4, half-maximal inhibitory concentration: > 40000 nM
Compound 4: a limit, no number; the forecaster's own chance of this, stated with the estimate: 85%; the middle value is on the limit's open side.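

Compound 4 gives > 40000 nM in this assay as a limit of the assay and not a number. No new step can be read from compound 1 or compound 3 to compound 4, since all four compounds share one reading: the limit of > 40000 nM in this assay, at which 4 of the 4 values shown sit. The compounds shown leave open whether any change to the shared core would bring a value out of this limit.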